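The compounds below may be only part of what the source reports. "The series", "measured", "known", "first", "only" and "open" are said of these compounds alone.

Compound 1, `CC(C)N(Cc1cccc(OCCCCCC(=O)O)c1)C(=O)c1ccc(-c2ccoc2)cc1`, gives > 26000 nM in an ADME assay on BJ cells (Homo sapiens) for cytotoxicity, read by CellTiter-Glo and resazurin assay, with a stated time of 72 h (on this read-out lower numbers stand for an effect already at smaller amounts and higher numbers for an effect only at larger amounts of compound), which is a limit of the assay. Compound 2, `CC(C)Oc1cccc(-c2ccc(C(=O)N(Cc3cccc(OCCCCCC(=O)O)c3)C(C)C)cc2)c1`, gives > 26000 nM in this assay, also a limit. Compound 3, `CCOC(=O)CCCCCOc1cccc(CN(C(=O)c2ccc(-c3ccoc3)cc2)C(C)C)c1`, gives > 26000 nM in this assay, again a limit.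

From compound 1 to compound 2 the change is 3-isopropoxyphenyl in place of furan-3-yl on an aromatic carbon; its step, a step that the two limits leave unreadable from compound 1 to compound 2, cannot be sized because of the limit of > 26000 nM in this assay, at which 3 of the 3 values shown sit. The cores of compound 1 and compound 3 differ by ethyl in place of hydrogen on an oxygen next to a carbonyl group, a step that is likewise unreadable, a step that the two limits leave unreadable from compound 1 to compound 3. Compound 4, `CCOC(=O)CCCCCOc1cccc(CN(C(=O)c2ccc(-c3cccc(OC(C)C)c3)cc2)C(C)C)c1`, carries the same kind of change as compound 2 does, (3-isopropoxyphenyl in place of furan-3-yl on an aromatic carbon), now on the core of compound 3. Among the measured compounds shown here, the expected step from compound 3 to compound 4 is a step that the limit leaves unreadable from compound 3 to compound 4, since none of the measured compounds showed an effect within the measured range. Compound 4 is therefore estimated at 40000 nM in this assay, between 20000 nM and 100000 nM.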

Compound 4, half-maximal effective concentration: > 26000 nM
Compound 4: no number, only a limit; the forecaster's own chance of this, stated with the estimate: 85%; the middle value does not contradict the limit.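

No step to compound 4 can be read, either from compound 3 or from compound 2, because none of the values gives a size: the limit of > 26000 nM in this assay, at which 4 of the 4 values shown sit.

The compounds shown leave open how either change, or any other, would act on the half-maximal effective concentration in this assay.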